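The source may report more compounds than this note shows. Statements on the series, on what has been measured and on what is new or still open speak of the compounds shown alone.

Two members of the series carry a number in an assay on Sf9 cells for inhibition of protein deacetylase HDAC6 (Homo sapiens), read by fluorescence, with a stated time of 40 min, tested at 100 nM; a higher number here means more inhibition at the concentration tested (going by the name of the read-out), a lower number less inhibition. Compound 1 `Cc1ccc(-c2nc(CNc3ccc(C(=O)NO)cc3)n(-c3ccccc3)n2)cc1` gives 62.2% in this assay, and compound 2 `CCc1ccc(-n2nc(-c3ccccc3)nc2CNc2ccc(C(=O)NO)cc2)cc1` gives 38.3%. Compound 1 stands highest of the two numbers; its nearest neighbour is compound 2, whose value lies beyond the scatter below it. The two measured compounds do not differ in one place only, so their values show no more than that the arrangement in compound 1 gives the larger inhibition of the two.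

Compound 3 `O=C(NO)c1ccc(NCc2nc(-c3ccccc3Cl)nn2-c2ccccc2)cc1` has not been measured in this assay. It differs from compound 1 in one place: 2-chlorophenyl in place of 4-methylphenyl on an aromatic carbon. Going by the values given here, nothing among the measured compounds bears directly on this exchange, so the expectation rests on compound 1 alone. The step of a number 8.2 percentage points lower from compound 1 to compound 3 (within the scatter) is expected to be modest, within or a little beyond the scatter, and downward rather than upward. Compound 3 is therefore estimated at 54% in this assay, with a range from 33% to 72%, pending the actual measurement.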

Compound 3, a percentage reported as inhibition, at one concentration (the size of the read-out at that concentration, not a potency): 75%
Compound 3: the middle estimate sits 21 percentage points below what was measured; measured number above the stated range.
By their numbers in this assay, from the lowest: compound 2; then compound 1; then compound 3.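

The exchange of 4-methylphenyl for 2-chlorophenyl, on the aromatic carbon between two ring nitrogen atoms, gives a number 12.8 percentage points higher from compound 1 to compound 3 (beyond the scatter) in this assay. Going by these compounds alone, this is the first one-place comparison, and it shows that this position accepts a substituted phenyl group other than 4-methylphenyl with no loss of inhibition at the concentration tested, and in this pair with a gain. Nothing at hand explains the step, which stands as an observation on this one pair only.

The exchange alters both the substituent on the phenyl ring and where it stands, so the compounds shown do not separate the two: 4-chlorophenyl and 2-methylphenyl at this position would be needed to tell whether the chlorine, the placement or the combination goes with the higher number. From the compounds shown here alone, it also remains open whether this position holds up with something other than a substituted phenyl group, such as a pyridine ring, a morpholine or a carboxylic acid, and whether the same exchange would give a step of similar direction with the ethylphenyl arrangement of compound 2.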